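Hydroxy for Nitro: Expected Tolerance of Compound 4

This account rests on a few compounds, and the source may have more. Where it says the series, first, only, none or still open, it means among the compounds named here.

Measured so far in an ADME assay on HEL cells (Homo sapiens) for cytotoxicity, with a stated time of 3 days; a higher number here means that more compound is tolerated, a lower number that less compound is tolerated:
compound 1, `COc1cccc(-c2cc(C)cn3c(CSCCc4ccccc4)cnc23)c1`: 100 ug/mL
compound 2, `Cc1cc(-c2ccccc2)c2ncc(CSCCc3ccccc3)n2c1`: 20 ug/mL
compound 3, `Cc1cc(-c2cccc([N+](=O)[O-])c2)c2ncc(CSCCc3ccccc3)n2c1`: 100 ug/mL

Compound 3 stands level with compound 1 at the digits shown, and the two together give the highest numbers of the three. Compound 2 sits apart: a 5.0-fold higher number from compound 2 to compound 3 (0.70 log units; beyond the scatter), and the same size of gap separates compound 1 from compound 2, since a 5.0-fold lower number from compound 1 to compound 2 (0.70 log units; beyond the scatter). Between compound 1 and compound 3 there is no change beyond the scatter, no change at the digits printed from compound 1 to compound 3 (within the scatter).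

Compound 4 `Cc1cc(-c2cccc(O)c2)c2ncc(CSCCc3ccccc3)n2c1` has not yet been tested in this assay. It differs from compound 3 in one place: hydroxy in place of nitro on an aromatic carbon. Within the data shown here, no measured step exchanges nitro for hydroxy, so the expectation rests on what the three compounds show. Both compounds carrying a group on that aromatic carbon, compound 1 and compound 3, are tolerated alike, while the unsubstituted compound 2 is tolerated less. On that basis compound 4 is expected to remain near compound 3, with a step of no change at the digits printed from compound 3 to compound 4 (within the scatter) that stays within the scatter. The estimate for compound 4 in this assay is 100 ug/mL, with a range from 20 ug/mL to 200 ug/mL, the lower end allowing for the possibility that the hydroxy compound behaves more like compound 2.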

Compound 4, minimum cytotoxic concentration: 20 ug/mL
For compound 4 the middle estimate is 5.0-fold (0.70 log units) above the measured one; measured number inside the range.
By their numbers in this assay, from the lowest: compounds 2 and 4 (each within the scatter of the next); then compounds 1 and 3 (each within the scatter of the next).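

In this assay, having a group on this aromatic carbon is not enough to keep the higher number, since nitro and hydroxy part with a 5.0-fold lower number from compound 3 to compound 4 (0.70 log units; beyond the scatter). The loss of only the methyl on the oxygen has a step of the same size, a 5.0-fold lower number from compound 1 to compound 4 (0.70 log units; beyond the scatter), so methoxy and hydroxy do not count as one kind of substituent here, and hydroxy set against hydrogen at this carbon gives no change at the digits printed from compound 2 to compound 4 (within the scatter). The four compounds now fall into two levels, with methoxy and nitro on one and hydrogen and hydroxy on the other, and nothing measured here accounts for that split.

Going by these compounds, whether an amine, a carboxylic acid or a fluorine at this carbon would join the methoxy and nitro pair or the hydrogen and hydroxy pair remains open, as does whether a longer ether such as ethoxy would follow methoxy. Also open, on these data alone, is whether the same two levels would appear with these groups on a different core, since all four compounds share one core and one thioether chain.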